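A few compounds are considered here, and "the series" means these few. Any claim that something is new, unique, unknown or untested is made for them only; others in the source may bear on it.

Compound 1 `O=C(CSc1nc(Nc2ccccc2)c2ccccc2n1)Nc1cccc(Br)c1` and compound 2 `C=CC(=O)Nc1cccc(NC(=O)CSc2nc(Nc3ccccc3Br)c3ccccc3n2)c1` share one core, and both are weak inhibitors in a functional assay on MDA-MB-231 cells (Homo sapiens) for inhibition, read by MTT assay, with a stated time of 72 h; a lower number here means a stronger inhibitor, a higher number a weaker inhibitor: compound 1 gives 17500 nM and compound 2 gives 15200 nM. Compound 2 has the lower of the two numbers, but the gap to compound 1 lies within the usual scatter, so neither stands apart. Compound 3 `C=CC(=O)Nc1cccc(NC(=O)CSc2nc(Nc3ccc(Cl)cc3Cl)c3ccccc3n2)c1` has not yet been measured. It differs from compound 2 in one place: 2,4-dichlorophenyl in place of 2-bromophenyl on a nitrogen on an aromatic ring. Among the compounds with values here, no measured pair shows what this change does, so no step beyond the scatter is expected in this assay. Compound 3 is therefore estimated to give 15000 nM, with a range from 6000 nM to 40000 nM. The expected step is a 1.0-fold lower number from compound 2 to compound 3 (0.01 log units; within the scatter).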

Compound 3, half-maximal inhibitory concentration: 23100 nM
The estimate for compound 3 lay 1.5-fold (0.19 log units) below the measured number; low and high end bracket the measured number.
By their numbers in this assay, from the lowest: compounds 2, 1 and 3 (each within the scatter of the next).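

Placing 2,4-dichlorophenyl instead of 2-bromophenyl on this nitrogen gives the first measured step at this position: in this assay there is a 1.5-fold higher number from compound 2 to compound 3 (0.18 log units; within the scatter). This exchange of one halogen-bearing phenyl ring for another therefore does not separate the two compounds. No measured evidence bears on this result.

Still open, going by these compounds, is whether any group at this position can move the number beyond the scatter. A phenyl ring carrying an amine or a carboxylic acid, for example, would test this with something other than halogens.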